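A seven-membered ring on the sulfonyl sulfur

This account rests on a few compounds, and the source may have more. Where it says the series, first, only, none or still open, it means among the compounds named here.

Two compounds have been measured in a functional assay on HL-60 cells (Homo sapiens) for inhibition, with a stated time of 72 h (on this read-out lower numbers stand for stronger inhibition of growth and higher numbers for weaker inhibition of growth), so far:
compound 1 `CCN(CC)S(=O)(=O)c1ccc(OC)c(NC(=O)c2[nH]c(C)c3c2CCCCC3=O)c1` gives 1360 nM
compound 2 `COc1ccc(S(=O)(=O)N2CC3(COC3)C2)cc1NC(=O)c1[nH]c(C)c2c1CCCCC2=O` gives 821 nM

Compound 2 has only compound 1 to be set against, and their two numbers lie within the scatter of each other, so neither stands apart. The next compound is compound 3 (`COc1ccc(S(=O)(=O)N2CCCCCC2)cc1NC(=O)c1[nH]c(C)c2c1CCCCC2=O`), which keeps the shared core. The structural change is a group of 7 heavy atoms (6 carbon, 1 nitrogen; one seven-membered non-aromatic ring with 1 hetero atom) in place of a group of 7 heavy atoms (5 carbon, 1 nitrogen, 1 oxygen; 2 four-membered non-aromatic rings with 1 hetero atom each), on a sulfonyl sulfur and nothing else differs. Within the data shown here, the one measured step at this place is a 1.7-fold lower number from compound 1 to compound 2 (0.22 log units; within the scatter) and it gives no sign of a real shift. Among the measured compounds shown here, no measured compound carries a seven-membered ring, so that single step is thin evidence. On it, no change beyond the scatter is expected in this assay for the new group. The expected step is a 1.1-fold higher number from compound 2 to compound 3 (0.04 log units; within the scatter) and it remains an estimate. Compound 3 is estimated at 900 nM with an expected range from 350 nM to 2400 nM in this read-out.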

Compound 3, concentration for 50% growth inhibition: 565 nM
The estimate for compound 3 lay 1.6-fold (0.20 log units) above the measured number; low and high end bracket the measured number.
By their numbers in this assay, from the lowest: compounds 3, 2 and 1 (each within the scatter of the next, the first and the last beyond it).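

In this assay, the sulfonyl sulfur now shows its first step beyond the scatter, a modest one, with azepan-1-yl in place of diethylamino (a 2.4-fold lower number from compound 1 to compound 3 (0.38 log units; beyond the scatter)). The step from the group with two four-membered rings to azepan-1-yl stays within the scatter (a 1.5-fold lower number from compound 2 to compound 3 (0.16 log units; within the scatter)), so these two ring groups cannot be told apart in this read-out, although only the first carries an oxygen. Nothing at hand explains either step.

The compounds shown leave open how a smaller ring on the sulfonyl sulfur, such as pyrrolidin-1-yl, piperidin-1-yl or morpholin-4-yl, would compare with azepan-1-yl. They also leave open whether a basic piperazin-1-yl or an open-chain dipropylamino group would fall within the same narrow range.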